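Removing One Methoxy Group: Expected Effect on Cell Toxicity

The compounds below may be only part of what the source reports. "The series", "measured", "known", "first", "only" and "open" are said of these compounds alone.

In a functional assay on HOP-62 cells (Homo sapiens) for inhibition, read by sulforhodamine B assay, with a stated time of 48 h (on this read-out lower numbers stand for higher toxicity in this test and higher numbers for lower toxicity in this test), compound 1 `COc1cc(-c2cc(/C=C/C(=O)c3ccc(N)cc3)[nH]n2)cc(OC)c1OC` gives 8700 nM, the lowest of the three numbers measured. Compound 2 `COc1ccc(-c2cc(/C=C/C(=O)c3ccc(OC)c(OC)c3)[nH]n2)cc1` gives 35300 nM, and compound 3 `COc1cc(-c2cc(/C=C/C(=O)c3ccc(Cl)c(Cl)c3)[nH]n2)cc(OC)c1OC` gives 42600 nM. The only single-place step among these is a 4.9-fold higher number from compound 1 to compound 3 (0.69 log units; beyond the scatter), and it concerns the other end of the molecule. Compound 4 `COc1ccc(-c2cc(/C=C/C(=O)c3ccc(N)cc3)[nH]n2)cc1OC` differs from compound 1 by hydrogen in place of methoxy on an aromatic carbon. Within the data shown here, no measured step touches a methoxy group on this ring; compound 2 carries one methoxy group there but also a different ketone side, so its 35300 nM gives only a loose hint that fewer methoxy groups go with a higher number. The step from compound 1 to compound 4 is therefore expected to be a 1.8-fold higher number from compound 1 to compound 4 (0.26 log units; within the scatter), a modest rise. Compound 4 is estimated at 16000 nM, within 5000 nM to 50000 nM.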

Compound 4, concentration lethal to 50% of the cells: 32000 nM
For compound 4 the middle estimate is 2.0-fold (0.30 log units) below the measured one; measured number inside the range.
By their numbers in this assay, from the lowest: compound 1; then compounds 4, 2 and 3 (each within the scatter of the next).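

In this assay, among these compounds, putting hydrogen in place of this one methoxy group gives a 3.7-fold higher number from compound 1 to compound 4 (0.57 log units; beyond the scatter), so this position, which no earlier step touched, does affect the read-out. With the rest of compound 1 unchanged, the loss of this group alone goes with lower toxicity in this test. Nothing available explains this shift.

On these data alone, whether a hydroxyl group, an ethoxy group or a fluorine atom at this place would keep the lower number remains open. So does whether removing either remaining methoxy group would have a similar effect.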